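The source may report more compounds than this note shows. Statements on the series, on what has been measured and on what is new or still open speak of the compounds shown alone.

Measured so far:
- compound 2, `Cc1cc(Cc2ccccc2)c(=O)n(CC(=O)Nc2ccc(Br)cc2)n1`: > 50000 nM
- compound 3, `Cc1cc(Cc2ccccc2)c(=O)n(CC(=O)Nc2ccc(F)cc2)n1`: > 50000 nM
- compound 1, `COc1cccc(Cc2cc(C(C)C)nn(CC(=O)Nc3ccc(Br)cc3)c2=O)c1`: 17400 nM

Compound 2 stands at a limit. In an assay on HL-60 cells for agonist activity at N-formyl peptide receptor 3 (Homo sapiens), read by calcium flux (a higher number here means that more compound is needed for the effect, a lower number that less compound is needed), compound 2 gives > 50000 nM, which is a limit of the assay and not a number. Compound 3 gives > 50000 nM in this assay, again a limit rather than a number. The step that the two limits leave unreadable from compound 2 to compound 3 is therefore unreadable. Going by the values given here, compound 1 is the one compound of the three with a number, 17400 nM, and it differs from compound 2 in more than one place, so no step to it is read. Two of the three values rest at the limit of > 50000 nM in this assay, at which 2 of the 3 values shown sit.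

Compound 4, `Cc1cc(Cc2cccc(Br)c2)c(=O)n(CC(=O)Nc2ccc(Br)cc2)n1`, is not yet measured. It differs from compound 2 by bromo in place of hydrogen on an aromatic carbon. Among the compounds with values here, no measured step bears on this change: the only single-place step is unreadable, and the starting point is a limit. The expected step is an at least 1.2-fold lower number from compound 2 to compound 4 (0.09 log units; that floor lies within the scatter), with no direction that the data support. Compound 4 is expected at 40000 nM, within 10000 nM to 50000 nM, with a real chance that only a limit is returned.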

Compound 4, half-maximal effective concentration: > 50000 nM
Compound 4 ended at the assay's limit; the forecaster's own chance of this, stated with the estimate: 60%; at least 1.2-fold (0.09 log units) between middle value and limit.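

No step can be read from compound 2 to compound 4, since both values are limits and not numbers: the limit of > 50000 nM in this assay, at which 3 of the 4 values shown sit.

Going by these compounds alone, whether 3-bromobenzyl in place of benzyl changes the read-out at all stays open, as does which difference sets compound 1, the only compound with a number, apart.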